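Chloro to Methyl on the Aryl Ring, Cytotoxicity Series

The source may report more compounds than this note shows. Statements on the series, on what has been measured and on what is new or still open speak of the compounds shown alone.

Working notes. Of the compounds shown here, two carry a number so far. Compound 1 `Cc1ccc(-c2cs/c(=N/NC(=O)CSc3nnnn3C)n2-c2ccccc2)cc1` in a functional assay on C6 cells (Rattus norvegicus) for cytotoxicity, read by MTT assay, with a stated time of 24 h, tested at 100 ug/mL (on this read-out lower numbers stand for a stronger effect and higher numbers for a weaker effect at the one concentration tested), gives 39.7%. Compound 2 `O=C(CSc1ncccn1)N/N=c1/scc(-c2ccc(Cl)cc2)n1-c1ccccc1` in this assay gives 45.5%; the gap to compound 1 lies within the scatter, so the two compounds cannot be told apart on this read-out. Within the data shown here, compound 1 and compound 2 differ in more than one place, and no single-change step between measured compounds is available.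

Compound 3 `Cc1ccc(-c2cs/c(=N/NC(=O)CSc3ncccn3)n2-c2ccccc2)cc1` is not yet measured. Relative to compound 2, (methyl in place of chloro on an aromatic carbon). Among the measured compounds shown here, no measured step isolates this change, so the expectation rests only on the two values given, which sit within the scatter of each other. The expected step of a number 2.5 percentage points lower from compound 2 to compound 3 (within the scatter) is therefore none beyond the scatter. Compound 3 is estimated at 43% in this assay, expected to fall between 31% and 55%.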

Compound 3, a percentage reported as activity, at one concentration (the size of the read-out at that concentration, not a potency): 45.9%
Compound 3: middle estimate off by 2.9 percentage points, on the low side, and the stated range covers the measured number.
By their numbers in this assay, from the lowest: compounds 1, 2 and 3 (each within the scatter of the next).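

Among these compounds, the single change from 4-chlorophenyl to 4-methylphenyl, on an aromatic carbon para to a large group, now reads directly as a number 0.4 percentage points higher from compound 2 to compound 3 (within the scatter) in this assay, so this pair cannot be told apart on this read-out. The group on the sulfur also has its own single-change reading: pyrimidin-2-yl in place of 1-methyl-1H-tetrazol-5-yl gives a number 6.2 percentage points higher from compound 1 to compound 3 (within the scatter), and this change does not separate its pair either. No separate evidence bears on these two steps.

On these data alone, whether an amine or a carboxylic acid at the aromatic position would move the read-out beyond the scatter remains open. Also open, as far as these compounds go, is how a longer alkyl chain on the sulfur, in place of either ring, would read at this single concentration.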